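A few compounds are considered here, and "the series" means these few. Any claim that something is new, unique, unknown or untested is made for them only; others in the source may bear on it.

Measured so far:
compound 1 `O=C(Nc1ccc2[nH]ncc2n1)[C@H]1CCCN1C(=O)C1(c2cccc(Cl)c2)CCCC1`: 0.159 nM
compound 2 `O=C(Nc1ccc2[nH]ncc2n1)[C@H]1CCCN1C(=O)C1(c2ccc(Cl)cc2)CC(F)(F)C1`: 0.316 nM

In an assay on isolated protein for inhibition of histone acetyltransferase p300 (Homo sapiens), with a stated time of 60 min (on this read-out higher numbers stand for weaker inhibition and lower numbers for stronger inhibition), compound 1 gives 0.159 nM, the lowest of the two numbers shown. Compound 2 gives 0.316 nM, which lies within the scatter of compound 1, so the two cannot be ranked. Compound 3 `O=C(Nc1ccc2[nH]nnc2c1)[C@H]1CCCN1C(=O)C1(c2cccc(Cl)c2)CCCC1` differs from compound 1 by a group of 9 heavy atoms (6 carbon, 3 nitrogen; one five-membered aromatic ring with 3 hetero atoms, one six-membered aromatic ring of carbon only) in place of a group of 9 heavy atoms (6 carbon, 3 nitrogen; one five-membered aromatic ring with 2 hetero atoms, one six-membered aromatic ring with 1 hetero atom), on an amide-type nitrogen; the two hold the same atoms, joined differently. Among the compounds with values here, no measured pair shows this change, so its size is not known from the data. The writer expects the change to cost potency beyond the scatter, with a step of a 19-fold higher number from compound 1 to compound 3 (1.28 log units; beyond the scatter). For compound 3 the estimate in this assay is 3 nM, with a range from 0.5 nM to 30 nM.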

Compound 3, half-maximal inhibitory concentration: 20 nM
Estimate against measurement, compound 3: 6.7-fold (0.82 log units) below, within the range that was stated.
By their numbers in this assay, from the lowest: compounds 1 and 2 (each within the scatter of the next); then compound 3.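

In this assay, the change on the amide-type nitrogen gives a 130-fold higher number from compound 1 to compound 3 (2.10 log units; beyond the scatter) and so shows that potency at this position depends on how these atoms are joined, not only on which atoms are present. The two groups have the same counts of heavy atoms, hydrogen-bond donors and acceptors, and the same net charge, so these counts do not account for the difference. Nothing available here explains the loss. On these data alone, it remains open which part of the rearrangement matters, and whether a simpler group on this nitrogen, such as a pyridine or a phenyl ring, would keep any potency.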